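Aryl for hydroxypropylsulfanyl on the benzylamide core

The source may report more compounds than this note shows. Statements on the series, on what has been measured and on what is new or still open speak of the compounds shown alone.

Compound 1 `CCCN(CCC)c1cc(C(F)(F)F)ccc1CNC(=O)C(C)c1ccc(NS(C)(=O)=O)c(F)c1` gives 0.3 nM in an assay on CHO cells for antagonist activity at transient receptor potential cation channel subfamily V member 1 (Homo sapiens), read by FLIPR; a lower number here means a stronger inhibitor, a higher number a weaker inhibitor. Among the compounds with values here, compound 2 `CCCCSc1cc(C(F)(F)F)ccc1CNC(=O)C(C)c1ccc(NS(C)(=O)=O)c(F)c1`, with butylsulfanyl in place of dipropylamino on an aromatic carbon, gives 1.9 nM in this assay; the step of a 6.3-fold higher number from compound 1 to compound 2 (0.80 log units; beyond the scatter) is the only one-place change measured so far. Compound 3 `CC(C(=O)NCc1ccc(C(F)(F)F)cc1SCCCO)c1ccc(NS(C)(=O)=O)c(F)c1`, carrying (3-hydroxypropyl)sulfanyl at the same position, is reported in this assay as "not active" (no number reported), so no number stands for it, and it sits outside the range covered by compound 1 and compound 2. Compound 4 `CC(C(=O)NCc1ccc(C(F)(F)F)cc1-c1ccc(F)c(Cl)c1)c1ccc(NS(C)(=O)=O)c(F)c1` differs from compound 3 by 3-chloro-4-fluorophenyl in place of (3-hydroxypropyl)sulfanyl on an aromatic carbon. Within the data shown here, no measured step bears directly on this change; the step from compound 1 to compound 2 concerns a different substituent and gives no guide to an aromatic replacement. What can be said is that compound 2, with a sulfur-linked chain lacking a hydroxyl, is active, while compound 3 is not, so the direction expected for compound 4 is toward a measurable number, with wide uncertainty. Compound 4 is therefore expected to give about 5 nM in this assay, estimated within 0.5 nM to 100 nM.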

Compound 4, inhibition constant: 0.6 nM
Beside the measured number, compound 4's estimate is 8.3-fold (0.92 log units) above it; the measured number falls inside the stated range.
By their numbers in this assay, from the lowest: compounds 1 and 4 (each within the scatter of the next); then compound 2.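

In this assay this aromatic carbon, ortho to a large group and meta to a trifluoromethyl group, also accepts a directly attached aromatic ring, and 3-chloro-4-fluorophenyl carries no hydrogen-bond donor or acceptor. Replacing butylsulfanyl with this ring gives a clear step (a 3.2-fold lower number from compound 2 to compound 4 (0.50 log units; beyond the scatter)), while replacing dipropylamino with it gives a step that does not separate the two groups (a 2.0-fold higher number from compound 1 to compound 4 (0.30 log units; within the scatter)). The change from (3-hydroxypropyl)sulfanyl has no size that can be read, as compound 3 has no number, and no measurement shown accounts for any of these differences.

Still open, from the compounds shown here alone, is whether the inactivity of compound 3 goes with its hydroxyl or with its chain, which an ether or an amine at the chain end could help separate. Also open, going by these compounds, is how much the chlorine and fluorine contribute, which a plain phenyl or a nitrile-bearing phenyl would address.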